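Benzamide sulfonamide series: methoxy to chloro exchange

The source may report more compounds than this note shows. Statements on the series, on what has been measured and on what is new or still open speak of the compounds shown alone.

Measured compounds
- compound 3, `COc1c(NS(=O)(=O)c2ccc(F)cc2)cc(-c2ccc3nc(NC(=O)C4CC4)sc3c2)cc1C(N)=O`: 2870 nM
- compound 1, `COc1c(NS(=O)(=O)C2CC2)cc(-c2ccc3nc(NC(C)=O)nn3c2)cc1C(N)=O`: "not determined" (no result reported)
- compound 2, `COc1c(NS(=O)(=O)c2ccc(F)cc2)cc(-c2ccc3nc(NC4CC4)sc3c2)cc1C(N)=O`: "not determined" (no result reported)

In a functional assay on U-87MG ATCC cells (Homo sapiens) for antiproliferative activity, read by MTT assay, with a stated time of 72 h (on this read-out lower numbers stand for stronger inhibition and higher numbers for weaker inhibition), compound 3 gives 2870 nM. For the measured compounds named here, this is the only number in the set; in this assay compound 1 gives "not determined" (no result reported) and compound 2 gives "not determined" (no result reported), so compound 3 cannot be ranked against anything and no step between measured compounds is available. Compound 3 therefore stands alone as the sole reference point for the series.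

Compound 4, `NC(=O)c1cc(-c2ccc3nc(NC(=O)C4CC4)sc3c2)cc(NS(=O)(=O)c2ccc(F)cc2)c1Cl`, is the next entry to be measured. It differs from compound 3 in one place: chloro in place of methoxy on an aromatic carbon. The shared core, the fluorophenylsulfonylamino group, the carbamoyl group and the cyclopropanecarboxamide-bearing bicycle are all kept; only the substituent on that aromatic carbon is exchanged.

Going by the values given here, with no measured step to lean on, the size of the change in this assay is an open question. A single-atom exchange of this kind on an already substituted ring is expected to move the read-out only modestly, and the direction is not predictable from the data at hand. The working expectation is a step from compound 3 to compound 4 of a 1.1-fold lower number from compound 3 to compound 4 (0.06 log units; within the scatter), within the usual scatter. Compound 4 is accordingly estimated at 2500 nM, with a range from 800 nM to 8000 nM.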

Compound 4, half-maximal inhibitory concentration: 17900 nM
For compound 4 the middle estimate is 7.2-fold (0.85 log units) below the measured one; the measured number lies above the stated range.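

In this assay, exchanging methoxy for chloro on the aromatic carbon ortho to a ((4-fluorophenyl)sulfonyl)amino group and ortho to a carbamoyl group gives a 6.2-fold higher number from compound 3 to compound 4 (0.79 log units; beyond the scatter). For the compounds shown here, this is the first readable step, and it shows that this position is not silent: with the rest of the structure kept, a change at this one carbon moves antiproliferative activity, and the methoxy compound holds the lower number and so the stronger inhibition. Nothing at hand bears on what lies behind this step, which therefore stands as an observation only.

A single pair cannot separate what is lost with the methoxy group from what is gained with the chloro group, and it gives no trend across substituents at this carbon. Values for a hydrogen, a fluoro group, an ethoxy group or an amine at the same position would show whether the number follows the methoxy group specifically, and whether any replacement can match or improve on compound 3.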